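The source may report more compounds than this note shows. Statements on the series, on what has been measured and on what is new or still open speak of the compounds shown alone.

Measured compounds:
compound 1 `Cc1ccc(NC(=O)CCc2cccc3c2B(O)OC3)cc1` — 860 nM
compound 2 `O=C(CCc1cccc2c1B(O)OC2)Nc1cccc(-c2ccccc2)c1` — 250 nM
compound 3 `O=C(CCc1cccc2c1B(O)OC2)Nc1ccc(-c2ccccc2)cc1` — 48000 nM

In a functional assay on SK-OV-3 cells (Homo sapiens) for antiproliferative activity, read by MTT assay, with a stated time of 72 h (a lower number here means a stronger inhibitor, a higher number a weaker inhibitor), compound 2 gives 250 nM, the lowest number of the three; compound 1 gives 860 nM and compound 3 gives 48000 nM. Among the compounds with values here, the one step between compounds that differ in a single place is a 56-fold higher number from compound 1 to compound 3 (1.75 log units; beyond the scatter).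

Compound 4 `N#Cc1cccc(-c2cccc(NC(=O)CCc3cccc4c3B(O)OC4)c2)c1` differs from compound 2 by cyano in place of hydrogen on an aromatic carbon. Within the data shown here, none of the measured steps bears on this change directly: the change from compound 1 to compound 3 concerns a phenyl entering in place of methyl, not a substituent on the outer ring of a biphenyl. Among the measured compounds shown here, the only anchor is the value of compound 2 in this assay, and the expectation is therefore that the step from compound 2 to compound 4 stays near or within the scatter, with no direction preferred, as a 1.2-fold higher number from compound 2 to compound 4 (0.08 log units; within the scatter). Compound 4 is estimated at 300 nM, with a range from 100 nM to 1000 nM.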

Compound 4, half-maximal inhibitory concentration: 120 nM
For compound 4 the middle estimate is 2.5-fold (0.40 log units) above the measured one; the measured number falls inside the stated range.
By their numbers in this assay, from the lowest: compound 4; then compound 2; then compound 1; then compound 3.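

In this assay, the change of phenyl to 3-cyanophenyl gives a 2.1-fold lower number from compound 2 to compound 4 (0.32 log units; beyond the scatter), a modest step in the direction of a stronger inhibitor. Within the data shown here, the one earlier step, phenyl in place of methyl, said nothing about a substituent on this outer ring; here a cyano on an aromatic carbon of that ring is tolerated and lowers the number. Nothing available accounts for this step. Going by these compounds, whether the lower number belongs to the nitrile itself or to any substituent at this place remains open, and a methoxy, an amine or a carboxylic acid at the same place would separate these readings. Also open, on these data alone, is whether a cyano on the outer ring of compound 3 would lower its number in the same way.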